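A few compounds are considered here, and "the series" means these few. Any claim that something is new, unique, unknown or untested is made for them only; others in the source may bear on it.

Compound 3 `Cc1ccccc1[C@@H]1CC[C@@H](C(=O)O)N1C(=O)CNC(=O)[C@@H](S)Cc1ccccc1` stands at the high end of the three measured diastereomers in an assay on isolated protein for inhibition of Neprilysin (Oryctolagus cuniculus) (a higher number here means a weaker inhibitor, a lower number a stronger inhibitor), where compound 3 gives 17 nM. Compound 1 `Cc1ccccc1[C@H]1CC[C@@H](C(=O)O)N1C(=O)CNC(=O)[C@@H](S)Cc1ccccc1` gives 5.3 nM in this assay, and compound 2 `Cc1ccccc1[C@@H]1CC[C@H](C(=O)O)N1C(=O)CNC(=O)[C@@H](S)Cc1ccccc1` gives 8.5 nM. The measured steps among them are small: a 1.6-fold higher number from compound 1 to compound 2 (0.21 log units; within the scatter), a 3.2-fold higher number from compound 1 to compound 3 (0.51 log units; beyond the scatter) and a 2.0-fold higher number from compound 2 to compound 3 (0.30 log units; within the scatter). In every pair the two molecules are identical in atoms and bonds and differ only in how the ring stereocentres are drawn the fact that compounds 1 and 2 differ only in the configuration as drawn the fact that compounds 1 and 3 differ only in the configuration as drawn (the fact that compounds 2 and 3 differ only in the configuration as drawn).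

Compound 4 `Cc1ccccc1[C@H]1CC[C@H](C(=O)O)N1C(=O)CNC(=O)[C@@H](S)Cc1ccccc1` is the remaining diastereomer of the shared core. From compound 3 the change is the two compounds have the same atoms and bonds and differ only in configuration as drawn: 2 of 3 stereo elements differ; a stereocentre at a saturated ring carbon is drawn S in compound 3 and R in compound 4; a stereocentre at a saturated ring carbon is drawn S in compound 3 and R in compound 4. Going by the values given here, the one earlier step that likewise inverted two ring stereocentres, the step from compound 1 to compound 2, stayed within the scatter, and the single inversions leading to compound 3 were at most modest. Compound 4 differs from compound 1 and from compound 2 at one ring stereocentre each, so it is expected to land near those two rather than beyond compound 3. The expected step is a 2.1-fold lower number from compound 3 to compound 4 (0.33 log units; beyond the scatter), a modestly lower number. Compound 4 is expected to give 8 nM, within a range from 3 nM to 25 nM.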

Compound 4, half-maximal inhibitory concentration: 25 nM
Beside the measured number, compound 4's estimate is 3.1-fold (0.49 log units) below it; measured number inside the range.
By their numbers in this assay, from the lowest: compounds 1, 2, 3 and 4 (each within the scatter of the next, the first and the last beyond it).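

Compound 4 completes the four ring diastereomers in this assay, and a second double inversion, a 1.5-fold higher number from compound 3 to compound 4 (0.17 log units; within the scatter), again stays within the scatter, so in both pairs where the two ring stereocentres are inverted together, the numbers cannot be told apart. Inverting a single ring stereocentre, by contrast, now gives two more steps beyond the scatter, a 2.9-fold higher number from compound 2 to compound 4 (0.47 log units; beyond the scatter) and a 4.7-fold higher number from compound 1 to compound 4 (0.67 log units; beyond the scatter), the second being the largest step in the set though still modest; the single inversion that goes against this pattern is a 2.0-fold higher number from compound 2 to compound 3 (0.30 log units; within the scatter), which stays within the scatter. Across all four compounds the spread is therefore modest, and whatever separates compound 1 from compound 4 lies in configuration alone: the fact that compounds 1 and 4 differ only in the configuration as drawn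

What the compounds shown leave open is whether this narrow spread would hold with the third stereocentre inverted, since all four share its drawn configuration. As far as these compounds go, it is also open whether the same ordering would survive if the methyl group gave way to a methoxy group, or the thiol to a carboxylic acid.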